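The compounds below may be only part of what the source reports. "The series", "measured", "known", "first", "only" and "open" are said of these compounds alone.

The measured compounds are compound 1 `O=C(CC(CC(=O)NC1Cc2ccccc2C1)c1ccc(Cl)cc1)NCCN1CCCCC1`, compound 2 `O=C(CC(CC(=O)NC1Cc2ccccc2C1)c1ccccc1)NCCN1CCCCC1` and compound 3 `CN(C(=O)CC(CC(=O)NCCN1CCCC1)c1ccccc1)C1Cc2ccccc2C1`.

In a functional assay on MCF7 cells (Homo sapiens) for inhibition (on this read-out higher numbers stand for weaker inhibition and lower numbers for stronger inhibition), compound 1 gives 35500 nM. For compound 2 the assay reports only a limit, > 100000 nM. For compound 3 the assay likewise reports only a limit, > 100000 nM. The change chloro in place of hydrogen on an aromatic carbon brought an at least 2.8-fold lower number from compound 2 to compound 1 (0.44 log units; beyond the scatter). The difference between the core of compound 2 and the core of compound 3 is not broken down here. Compound 4 `CN(C(=O)CC(CC(=O)NCCN1CCCC1)c1ccc(Cl)cc1)C1Cc2ccccc2C1` differs from compound 3 by chloro in place of hydrogen on an aromatic carbon, the same change. Since compound 3 sits at the limit of > 100000 nM in this assay, at which 2 of the 3 values shown sit, the step to compound 4 can only be judged from the measured pair. The expected step is an at least 1.6-fold lower number from compound 3 to compound 4 (0.22 log units; that floor lies within the scatter), in this assay. Compound 4 is expected to give about 60000 nM, between 20000 nM and 200000 nM.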

Compound 4, half-maximal inhibitory concentration: 76700 nM
Estimate against measurement, compound 4: 1.3-fold (0.11 log units) below, and the stated range covers the measured number.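

On the core of compound 3, the phenyl to 4-chlorophenyl change gave an at least 1.3-fold lower number from compound 3 to compound 4 (0.11 log units; that floor lies within the scatter), which points the same way as the step on the core of compound 2. Set side by side in this assay, the two steps read: the same change on two cores in this assay, an at least 2.8-fold lower number (0.44 log units; beyond the scatter) from compound 2 to compound 1 and an at least 1.3-fold lower number (0.11 log units; that floor lies within the scatter) from compound 3 to compound 4; the limit leaves it open whether they differ. From the compounds shown here alone, the true size of the step on either core stays unknown, because each unsubstituted parent is reported only as a limit: the limit of > 100000 nM in this assay, at which 2 of the 4 values shown sit.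

The compounds shown leave open whether fluoro, bromo or methoxy in the same place would give a similar step. They also leave open how a morpholine in place of the saturated amine ring on the side chain would read in this assay.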